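The compounds below may be only part of what the source reports. "The series", "measured", "known", "first", "only" and "open" are said of these compounds alone.

Measured so far:
compound 1, `COc1ccc(-c2cn3ccnc3c(-c3ccc4ncn(C5CCCCC5)c4c3)n2)cc1`, gives 80.9%
compound 2, `Fc1ccc(-c2cn3ccnc3c(-c3ccc4ncn(C5CCCCC5)c4c3)n2)cc1`, gives 7.94%
compound 3, `c1cn2cc(-c3ccsc3)nc(-c3ccc4ncn(C5CCCCC5)c4c3)c2n1`, gives 6.09%

All three were tested in a functional assay on U-251 cells (Homo sapiens) for inhibition, read by sulforhodamine B assay, with a stated time of 48 h, tested at 10 uM; a lower number here means less inhibition, a higher number more inhibition at the concentration tested (going by the name of the read-out). Compound 3 sits at the low end of these three numbers together with compound 2: the step of a number 1.9 percentage points lower from compound 2 to compound 3 (within the scatter), so the two cannot be told apart, while compound 1 stands far above both, as the step of a number 74.8 percentage points lower from compound 1 to compound 3 (beyond the scatter) shows.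

The next compound, compound 4, `Brc1ccc(-c2cn3ccnc3c(-c3ccc4ncn(C5CCCCC5)c4c3)n2)cc1`, differs from compound 3 in one place: 4-bromophenyl in place of thiophen-3-yl on an aromatic carbon.

Among the measured compounds shown here, two measured steps bear on this change. The step of a number 73 percentage points lower from compound 1 to compound 2 (beyond the scatter) shows that a halogen in the para position of the phenyl ring gives a low number, and the step of a number 1.9 percentage points lower from compound 2 to compound 3 (within the scatter) shows that thiophen-3-yl and 4-fluorophenyl give numbers that cannot be separated. Since compound 4 carries a halogen in the same place as compound 2, the value for compound 4 in this assay is expected to stay low, with a step of a number 5.9 percentage points higher from compound 3 to compound 4 (within the scatter) that is estimated to lie within the scatter. Compound 4 is therefore estimated at 12%, in a range from 0% to 45%.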

Compound 4, a percentage reported as inhibition, at one concentration (the size of the read-out at that concentration, not a potency): 23.7%
Beside the measured number, compound 4's estimate is 11.7 percentage points below it, within the range that was stated.
By their numbers in this assay, from the lowest: compounds 3 and 2 (each within the scatter of the next); then compound 4; then compound 1.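

The halogen on the phenyl ring turns out to matter, not just its presence: in this assay, the step with bromo in place of fluoro is a number 15.8 percentage points higher from compound 2 to compound 4 (beyond the scatter), so these two halogens can be told apart at this position. The 4-bromophenyl group also separates from thiophen-3-yl, with a number 17.6 percentage points higher from compound 3 to compound 4 (beyond the scatter), yet it recovers only part of what methoxy gives, as the step of a number 57.2 percentage points lower from compound 1 to compound 4 (beyond the scatter) shows. No measurement here explains why these groups differ.

The compounds shown leave open where a chloro or iodo group would fall among these numbers, and whether an amine or a carboxylic acid at the same place could match methoxy. From the compounds shown here alone, each number also comes from a single concentration, so how potency compares across the series remains open.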